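The source may report more compounds than this note shows. Statements on the series, on what has been measured and on what is new or still open speak of the compounds shown alone.

Measured compounds in this series, with their results in an assay on isolated protein for displacement of a labelled ligand from 5-hydroxytryptamine receptor 6 (Homo sapiens); a lower number here means a stronger inhibitor, a higher number a weaker inhibitor:
- compound 1, `O=S(=O)(c1cccc(F)c1)c1ccc2c(c1)CCC[C@H]2CNCCO`, gives 0.126 nM
- compound 2, `NCC(=O)NC[C@@H]1CCCc2cc(S(=O)(=O)c3cccc(F)c3)ccc21`, gives 0.316 nM
- compound 3, `CNC(=O)NC[C@@H]1CCCc2cc(S(=O)(=O)c3cccc(F)c3)ccc21`, gives 0.398 nM

Compound 3 holds the highest number of the three in this assay. It is separated from compound 2 by a 1.3-fold higher number from compound 2 to compound 3 (0.10 log units; within the scatter), while against compound 1 it stands further off, by a 3.2-fold higher number from compound 1 to compound 3 (0.50 log units; beyond the scatter); compound 2 likewise trails compound 1 by a 2.5-fold higher number from compound 1 to compound 2 (0.40 log units; beyond the scatter). Compound 4, `CC(C)(O)C(=O)NC[C@@H]1CCCc2cc(S(=O)(=O)c3cccc(F)c3)ccc21`, is not yet measured. Its difference from compound 3 is 1-hydroxy-1-methylethyl in place of methylamino on a carbonyl carbon, so the amide is kept and only the group on the carbonyl carbon changes. Among the compounds with values here, the one step bearing on a swap at this carbon is the one from compound 2 to compound 3, which stayed within the scatter, and all three measured compounds sit close together. Within the data shown here, no step of the measured set points in a clear direction, so the expected step in this assay is a 1.0-fold higher number from compound 3 to compound 4 (0.00 log units; within the scatter), essentially none beyond the scatter. Compound 4 is therefore estimated at 0.4 nM, expected to fall between 0.15 nM and 1.1 nM.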

Compound 4, inhibition constant: 2 nM
Estimate against measurement, compound 4: 5.0-fold (0.70 log units) below, outside the stated range (above it).
By their numbers in this assay, from the lowest: compound 1; then compounds 2 and 3 (each within the scatter of the next); then compound 4.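

In this assay the group on the carbonyl carbon proves not to be indifferent: methylamino and aminomethyl lay within the scatter of each other, but 1-hydroxy-1-methylethyl in that place gives a 5.0-fold higher number from compound 3 to compound 4 (0.70 log units; beyond the scatter) and also a 6.3-fold higher number from compound 2 to compound 4 (0.80 log units; beyond the scatter) on the same carbon. Set against the 2-hydroxyethyl on the amine nitrogen, the (1-hydroxy-1-methylethyl)carbonyl group gives a 16-fold higher number from compound 1 to compound 4 (1.20 log units; beyond the scatter) as the only large step in the series, which leaves compound 4 with the highest number of the four. Nothing available explains why this group costs more than the other two.

On these data alone, it remains open whether the step follows the hydroxyl or the branched carbon of the new group. The compounds shown also do not tell how an isopropyl, a hydroxymethyl or a dimethylamino group would behave on the same carbonyl carbon.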